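Aryl in Place of Cyclopropyl on the Saturated Ring Carbon

The compounds below may be only part of what the source reports. "The series", "measured", "known", "first", "only" and "open" are said of these compounds alone.

Measured compounds:
- compound 1 `CN1C(=O)C(C2CC2)N(C)c2nc(Nc3ccc(S(N)(=O)=O)cc3)ncc21` gives 136 nM in an assay on Sf9 cells for inhibition of serine/threonine-protein kinase 4 (Homo sapiens), read by luminescence and ADP-Glo, with a stated time of 1 h, in the presence of a further agent that is not named here; a higher number here means a weaker inhibitor, a lower number a stronger inhibitor
- compound 2 `CN1CC(=O)N(C)c2cnc(Nc3ccc(S(N)(=O)=O)cc3)nc21` gives 495 nM in this assay
- compound 3 `CN1C(=O)C(c2cccc(C(F)(F)F)c2)N(C)c2nc(Nc3ccc(S(N)(=O)=O)cc3)ncc21` gives 2710 nM in this assay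

Compound 1 holds the lowest number of the three. Its nearest neighbour is compound 2, with a 3.6-fold higher number from compound 1 to compound 2 (0.56 log units; beyond the scatter); furthest is compound 3, with a 20-fold higher number from compound 1 to compound 3 (1.30 log units; beyond the scatter). Both steps lie beyond the scatter, so compound 1 is the strongest inhibitor among the measured set.

Compound 4 `CCc1ccccc1C1C(=O)N(C)c2cnc(Nc3ccc(S(N)(=O)=O)cc3)nc2N1C` differs from compound 1 in one place: 2-ethylphenyl in place of cyclopropyl on a saturated ring carbon. Going by the values given here, the step that bears most directly on this is the one from compound 1 to compound 3, also an aryl group in place of cyclopropyl on the same saturated ring carbon, which gave a 20-fold higher number from compound 1 to compound 3 (1.30 log units; beyond the scatter). The step of a 5.5-fold higher number from compound 2 to compound 3 (0.74 log units; beyond the scatter) points the same way, an aryl group weaker than hydrogen at that position. Among the compounds with values here, no measured pair separates 2-ethylphenyl from 3-(trifluoromethyl)phenyl, so the size of the step for compound 4 is uncertain, but its direction is expected to follow compound 3.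

For compound 4 a large weakening is expected, a 15-fold higher number from compound 1 to compound 4 (1.17 log units; beyond the scatter). The estimate for compound 4 in this assay is 2000 nM, with a range from 600 nM to 7000 nM.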

Compound 4, half-maximal inhibitory concentration: 51 nM
Compound 4: the middle estimate sits 39-fold (1.59 log units) above what was measured; measured number below the stated range.
By their numbers in this assay, from the lowest: compound 4; then compound 1; then compound 2; then compound 3.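

In this assay an aryl group on the saturated ring carbon is no loss in itself: 2-ethylphenyl in place of cyclopropyl gives a 2.7-fold lower number from compound 1 to compound 4 (0.43 log units; beyond the scatter) and makes compound 4 the strongest inhibitor of the four, its steps to all others lying beyond the scatter. The two aryl groups part sharply at this one carbon, with a 53-fold lower number from compound 3 to compound 4 (1.73 log units; beyond the scatter) between them, and the step of a 9.7-fold lower number from compound 2 to compound 4 (0.99 log units; beyond the scatter) reverses the order of aryl and hydrogen seen with compound 3, so an aryl group weaker than hydrogen holds for 3-(trifluoromethyl)phenyl only, and 2-ethylphenyl goes against it. Nothing on hand explains why these two aryl groups differ so widely.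

The two aryl groups differ both in their substituent and in where it stands on the phenyl ring, so unsubstituted phenyl, 3-ethylphenyl and 2-(trifluoromethyl)phenyl would be needed to pull those two changes apart. Also open, as far as these compounds go, is whether the gain extends to a shorter or more heteroatom-bearing substituent on the phenyl ring, such as 2-methylphenyl or 2-methoxyphenyl.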